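The source may report more compounds than this note shows. Statements on the series, on what has been measured and on what is new or still open speak of the compounds shown alone.

Of the compounds shown here, two have been measured in a functional assay on DLD-1 cells (Homo sapiens) for cytotoxicity, read by MTT assay, with a stated time of 48 h; on this read-out lower numbers stand for stronger inhibition and higher numbers for weaker inhibition. Compound 1 `C=CCOc1ccc2c(NCCN(C)C)ccnc2c1` gives 1530 nM in this assay. Compound 2 `CCOc1ccc2c(Cl)ccnc2c1` gives 2750 nM in this assay. These two numbers lie within the usual scatter of each other, so neither compound can be set apart from the other on this read-out. Within the data shown here, compound 1 and compound 2 differ in two places at once, so no single-change step between measured compounds is available for comparison.

The next compound, compound 3 `CCOc1ccc2c(NCCN(C)C)ccnc2c1`, is reached from compound 2 by one change: (2-(dimethylamino)ethyl)amino in place of chloro on an aromatic carbon. Compound 3 thereby carries the same entering group that compound 1 already bears, while keeping the remainder of compound 2. Since compound 1 and compound 2, which differ in both of these places, fall within the scatter of each other, no large movement in this assay is anticipated. The number for compound 3 in this assay is expected to be 1600 nM, with a range from 600 nM to 4000 nM. The step is expected to be a 1.7-fold lower number from compound 2 to compound 3 (0.24 log units; within the scatter), toward a lower number if toward anything, and not beyond the scatter.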

Compound 3, half-maximal inhibitory concentration: 6240 nM
For compound 3 the middle estimate is 3.9-fold (0.59 log units) below the measured one; measured number outside the range, above it.
By their numbers in this assay, from the lowest: compounds 1 and 2 (each within the scatter of the next); then compound 3.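

In this assay, (2-(dimethylamino)ethyl)amino in place of chloro on the aromatic carbon opposite the ring nitrogen gives a 2.3-fold higher number from compound 2 to compound 3 (0.36 log units; beyond the scatter), so with the rest of compound 2 kept, this entering chain does not lower the number and chloro is the better of the two groups at this position. The other step shows that the result also depends on the far end of the molecule: with the (2-(dimethylamino)ethyl)amino chain held constant, methyl in place of vinyl on the saturated chain carbon bound to an oxygen on an aromatic ring gives a 4.1-fold higher number from compound 1 to compound 3 (0.61 log units; beyond the scatter), a modest move beyond the scatter, like the first. Nothing at hand accounts for either step.

As far as these compounds go, it remains open whether a morpholine in place of the dimethylamino end, or a longer chain between the two nitrogens, would recover the number lost on leaving chloro. From the compounds shown here alone, a propyl group on the oxygen would show whether the vinyl end itself or only the chain length goes with the lower number, and whether the chloro and amine groups rank the same way when vinyl is present also remains open.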